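Replacing an Ester Side Chain with a Carboxylic Acid

A few compounds are considered here, and "the series" means these few. Any claim that something is new, unique, unknown or untested is made for them only; others in the source may bear on it.

Compound 2, `CCOC(=O)/C=C/c1ccncc1-c1ccc2ccccc2c1`, has the largest value among the three compounds measured in an assay on a protein complex for inhibition of CDK8/Cyclin C (Homo sapiens), with a stated time of 1 h, tested at 10 uM (on this read-out higher numbers stand for more inhibition at the one concentration tested (going by the name of the read-out) and lower numbers for less inhibition), giving 102%, although its gap to compound 1 is within the scatter. Compound 1, `CN1CCN(C(=O)/C=C/c2ccncc2-c2ccc3ccccc3c2)CC1`, gives 101%, and compound 3, `O=C(O)CCNC(=O)/C=C/c1ccncc1-c1ccc2ccccc2c1`, gives 91%. Compound 4, `O=C(O)CCc1ccncc1-c1ccc2ccccc2c1`, differs from compound 2 as follows: 2-carboxyethyl in place of 2-(ethoxycarbonyl)ethenyl on an aromatic carbon. The step that bears on this most is the arrival of an acid-bearing chain in compound 3: a number 11 percentage points lower from compound 2 to compound 3 (beyond the scatter). The other steps, a number 1 percentage points higher from compound 1 to compound 2 (within the scatter) and a number 10 percentage points lower from compound 1 to compound 3 (within the scatter), show that changes at this end of the molecule move the number little. A small drop of similar size is therefore expected for compound 4, a step of a number 14 percentage points lower from compound 2 to compound 4 (beyond the scatter). Compound 4 is estimated to give 88%, with a range from 70% to 100%.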

Compound 4, a percentage reported as inhibition, at one concentration (the size of the read-out at that concentration, not a potency): 101%
Compound 4: middle estimate off by 13 percentage points, on the low side; the whole stated range lies below it.
By their numbers in this assay, from the lowest: compounds 3, 1, 4 and 2 (each within the scatter of the next, the first and the last beyond it).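

In this assay the change to 2-carboxyethyl on the aromatic carbon opposite the ring nitrogen gives a number 1 percentage points lower from compound 2 to compound 4 (within the scatter). The earlier compounds shown here varied only the group on the carbonyl carbon, whereas here the chain itself is altered, losing a double bond and ending in a carboxylic acid instead of an ester, and the number stays within the scatter. Nothing measured here explains this result. On these data alone, whether an amine or a longer chain at this carbon would also hold the number remains open. A single test concentration also leaves open whether compound 2 and compound 4 differ in potency.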